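Isoxazole for pyrazole on the fused core of compound 1

The compounds below may be only part of what the source reports. "The series", "measured", "known", "first", "only" and "open" are said of these compounds alone.

Compound 1 `Cn1ccc(-c2cccc3c2CCC3c2ncc[nH]2)n1` is the starting point. In a functional assay on CHO cells for agonist activity at Alpha-1A adrenergic receptor (Homo sapiens), read by FLIPR and calcium flux (on this read-out higher numbers stand for larger maximal responses and lower numbers for smaller maximal responses), compound 1 gives 19%, the lowest of the two single numbers in the set. The nearest single number belongs to compound 2 `Cc1c(OCC2=NCCN2)ccc(Cl)c1NS(C)(=O)=O`, which in this assay gives 60%, a gap beyond the scatter. Compound 3 `CS(=O)(=O)Nc1cccc2c1CCCC2c1ncc[nH]1` has been run more than once; in this assay compound 3 gives 47%; 79%; 79% (3 entries), and the several entries of compound 3 in this assay, 47%; 79%; 79% (3 entries) shows how widely repeats of one compound can spread in this read-out.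

Compound 4 `Cc1oncc1-c1cccc2c1CCC2c1ncc[nH]1` has not yet been measured. It differs from compound 1 by 5-methyl-1,2-oxazol-4-yl in place of 1-methyl-1H-pyrazol-3-yl on an aromatic carbon. Both groups are one five-membered aromatic ring with 2 hetero atoms, 0 hydrogen-bond donors and 2 hydrogen-bond acceptors, with no net charge; the place on the core is unchanged. Among the measured compounds shown here, no comparable step between measured compounds exists here. The step in this assay is therefore expected to be small, most likely none beyond the scatter in either direction. Compound 4 is estimated at 25%, within 8% to 50%, an expected step of a number 6 percentage points higher from compound 1 to compound 4 (within the scatter).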

Compound 4, largest response reached (Emax), in percent of the reference or control that the assay uses: 63%
Compound 4: the middle estimate sits 38 percentage points below what was measured; measured number above the stated range.
By their numbers in this assay, from the lowest: compound 1; then compounds 2 and 4 (each within the scatter of the next).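

In this assay the shared core gives a number 44 percentage points higher from compound 1 to compound 4 (beyond the scatter) when 5-methyl-1,2-oxazol-4-yl replaces 1-methyl-1H-pyrazol-3-yl on the aromatic carbon. This position therefore does not treat the two groups alike, even though each is one five-membered aromatic ring with 2 hetero atoms, 0 hydrogen-bond donors and 2 hydrogen-bond acceptors, with no net charge. The step rests on one entry for each compound, and repeats in this read-out can spread widely, as shown by: the several entries of compound 3 in this assay, 47%; 79%; 79% (3 entries)

The two groups differ both in their ring atoms and in where the methyl sits, and the compounds shown do not separate these two differences. Also open, from the compounds shown here alone, is how this position responds to a group other than a five-membered aromatic ring, such as an amine or a carboxylic acid.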